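A Fluorine Added to Compound 2's Phenyl Group

The source may report more compounds than this note shows. Statements on the series, on what has been measured and on what is new or still open speak of the compounds shown alone.

Compound 2 `CO/N=C(/COc1ccc2oc(-c3ccccc3)cc(=O)c2c1)c1ccccc1` gives 8200000 nM in a functional assay on SK-HEP1 cells (Homo sapiens) for antiproliferative activity (on this read-out lower numbers stand for stronger inhibition of growth and higher numbers for weaker inhibition of growth), the highest of the two numbers measured: compound 1 `CO/N=C(\C)COc1ccc2oc(-c3ccccc3)cc(=O)c2c1` gives 800000 nM, and the step of a 10-fold higher number from compound 1 to compound 2 (1.01 log units; beyond the scatter) follows the phenyl in place of methyl on a carbon with a double bond to nitrogen. Compound 3 `CO/N=C(/COc1ccc2oc(-c3ccccc3)cc(=O)c2c1)c1ccc(F)cc1` differs from compound 2 by fluoro in place of hydrogen on an aromatic carbon, placed para to a large group. Within the data shown here, no measured step touches such a change, so compound 3 is expected to show a step of a 1.0-fold lower number from compound 2 to compound 3 (0.01 log units; within the scatter) that stays within the scatter. Compound 3 is thus estimated at 8000000 nM, with a range from 3000000 nM to 20000000 nM.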

Compound 3, concentration for 50% growth inhibition: 7910000 nM
Compound 3: the middle estimate sits 1.0-fold (0.00 log units) above what was measured; low and high end bracket the measured number.
By their numbers in this assay, from the lowest: compound 1; then compounds 3 and 2 (each within the scatter of the next).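

In this assay, among these compounds, fluoro in place of hydrogen on an aromatic carbon, para to a large group, gives a 1.0-fold lower number from compound 2 to compound 3 (0.02 log units; within the scatter) and so stays within the scatter; this is the first sign that the phenyl group can carry a change at this position without moving the read-out. The large difference from the methyl compound also survives, with 4-fluorophenyl in place of methyl giving a 9.9-fold higher number from compound 1 to compound 3 (1.00 log units; beyond the scatter) on the same read-out. The compounds shown leave open whether an amine or a carboxylic acid at this position would leave the number equally unchanged. Nothing available explains why fluoro leaves the number where it was.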